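Replacing a Pyridazinyl Amide with a Phenethyl Amide

The source may hold more compounds than are shown below. What is called first, only, known or untested is meant among the compounds shown, and "the series" means these compounds.

Three compounds built on one shared core were tested in an assay for activation of interferon regulatory factor 3 (Homo sapiens), read by a luciferase reporter, with a stated time of 20 h; on this read-out lower numbers stand for an effect already at smaller amounts and higher numbers for an effect only at larger amounts of compound. Compound 1 `CCCn1c(NC(=O)c2cc(C)nn2CC)nc2cc(C(=O)OC)cc(OC)c21` reaches only the assay limit of > 100000 nM. Compound 2 `CCCn1c(NC(=O)c2cccnn2)nc2cc(C(N)=O)cc(OC)c21` likewise gives the limit > 100000 nM. Compound 3 `COc1cc(C(N)=O)cc2nc(NC(=O)c3cccnn3)n(CCCNC(=O)OCc3ccccc3)c12` also sits at the limit > 100000 nM. Within the data shown here, the single measured change between neighbours, a step that the two limits leave unreadable from compound 2 to compound 3, runs between two limits and so yields no readable size. Compound 3 thus stands at the limit of > 100000 nM in this assay, at which 3 of the 3 values shown sit, without a number of its own. Compound 4 `COc1cc(C(N)=O)cc2nc(NC(=O)CCc3ccccc3)n(CCCNC(=O)OCc3ccccc3)c12` differs from compound 3 by phenethyl in place of pyridazin-3-yl on a carbonyl carbon. Among the measured compounds shown here, no measured step touches this amide substituent, so the data give no direction for the change. Compound 4 is expected to remain near the limit, with an estimated 100000 nM ranging from 20000 nM to 300000 nM. The step of a number no higher from compound 3 to compound 4 (the limit leaves the size open) is accordingly expected to be slight.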

Compound 4, half-maximal effective concentration: > 100000 nM
Compound 4: a limit, no number (the forecaster's own chance of this, stated with the estimate: 80%); the middle value lies on the limit itself.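

Compound 3 and compound 4 both give only a limit, so no step between them can be read: the limit of > 100000 nM in this assay, at which 4 of the 4 values shown sit.

The compounds shown leave open whether phenethyl in place of pyridazin-3-yl on the carbonyl carbon changes the effect in this assay at all.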